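Series notes: the step from compound 3 to compound 4

This account rests on a few compounds, and the source may have more. Where it says the series, first, only, none or still open, it means among the compounds named here.

In a functional assay on Rec1 cells (Homo sapiens) for inhibition, read by luminescence and CellTiter-Glo, with a stated time of 72 h (a lower number here means a stronger inhibitor, a higher number a weaker inhibitor), compound 3 `O=C(CCl)Nc1ccc(Cn2nc(-c3ccc(Oc4ccccc4)cc3)cc2C(=O)O)cc1` has the lowest number shown, 4000 nM, while compound 2 `C/C=C/C(=O)Nc1cccc(Cn2nc(-c3ccc(Oc4ccccc4)cc3)cc2C(=O)O)c1` stands higher at 26000 nM. Compound 1 `C=CC(=O)Nc1ccc(Cn2nc(-c3ccc(Oc4ccccc4)cc3)cc2C(=O)O)cc1` gives > 60000 nM, which is a limit. Compound 4 `C=CC(=O)Nc1cccc(Cn2nc(-c3ccc(Oc4ccccc4)cc3)cc2C(=O)O)c1` differs from compound 3 as follows: 3-((vinylcarbonyl)amino)phenyl in place of 4-(((chloromethyl)carbonyl)amino)phenyl on a saturated chain carbon bound to an aromatic nitrogen, with 3-((vinylcarbonyl)amino)phenyl in place of 4-(((chloromethyl)carbonyl)amino)phenyl on a saturated chain carbon bound to an aromatic nitrogen. Among the compounds with values here, the only measured step bearing on this exchange is an at least 15-fold lower number from compound 1 to compound 3 (1.17 log units; beyond the scatter), which is large and beyond the scatter and runs opposite to the present change. A large step to a higher number is therefore expected in this assay, and the expected step is a 6.3-fold higher number from compound 3 to compound 4 (0.80 log units; beyond the scatter). Compound 4 is estimated at 25000 nM, with an expected range of 8000 nM to 60000 nM.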

Compound 4, half-maximal inhibitory concentration: 33100 nM
For compound 4 the middle estimate is 1.3-fold (0.12 log units) below the measured one, and the stated range covers the measured number.
By their numbers in this assay, from the lowest: compound 3; then compounds 2 and 4 (each within the scatter of the next). At a limit, above all of these: compound 1.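

In this assay, 3-((vinylcarbonyl)amino)phenyl in place of 4-(((chloromethyl)carbonyl)amino)phenyl gives an 8.3-fold higher number from compound 3 to compound 4 (0.92 log units; beyond the scatter), a change of both group and place. Vinyl in place of prop-1-en-1-yl on a carbonyl carbon gives a 1.3-fold higher number from compound 2 to compound 4 (0.10 log units; within the scatter), so this exchange shows no readable difference. 3-((vinylcarbonyl)amino)phenyl in place of 4-((vinylcarbonyl)amino)phenyl gives an at least 1.8-fold lower number from compound 1 to compound 4 (0.25 log units; that floor lies within the scatter), which is only a floor, as the number for compound 1 is a limit: the limit of > 60000 nM in this assay, at which 1 of the 4 values shown sits.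

From the compounds shown here alone, how much of the step to compound 4 belongs to the chloromethyl group and how much to its place remains open. Also open, going by these compounds, is whether bromomethyl on the carbonyl carbon would match chloromethyl.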